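A Larger Substituent on the Thiourea of Compound 2

This account rests on a few compounds, and the source may have more. Where it says the series, first, only, none or still open, it means among the compounds named here.

Among the measured compounds shown here, in a functional assay on the whole organism (stomach) with Rattus norvegicus as the target (a higher number here means that more compound is needed for the effect, a lower number that less compound is needed), compound 2 `C/N=C(\S)NCCCCCn1nc(-c2ccccc2)ccc1=O` gives 35.3 mg/kg, the only number among the three measured compounds. Compound 1 `C/N=C(\S)NCCCCn1nc(C)ccc1=O` reaches only the limit > 100 mg/kg in this assay. Compound 3 `C/N=C(/NC#N)NCCCCCCn1nc(-c2ccccc2)ccc1=O` likewise gives the limit > 100 mg/kg. For the measured compounds named here, the one measured step, an at least 2.8-fold higher number from compound 2 to compound 3 (0.45 log units; beyond the scatter), is a different exchange and does not match the change toward compound 4 `CC(C)(C)/N=C(\S)NCCCCn1nc(-c2ccccc2)ccc1=O`, which carries a group of 8 heavy atoms (5 carbon, 2 nitrogen, 1 sulfur; no ring) in place of a group of 6 heavy atoms (3 carbon, 2 nitrogen, 1 sulfur; no ring), on a saturated chain carbon, four bonds along the chain from an aromatic nitrogen. Going by the values given here, no measured step bears directly on it, and the prevalence of limits the limit of > 100 mg/kg in this assay, at which 2 of the 3 values shown sit, is the only guide. Compound 4 is therefore expected to give a step of a 1.3-fold higher number from compound 2 to compound 4 (0.11 log units; within the scatter) in this assay, with an estimated value of 45 mg/kg, ranging from 15 mg/kg to 100 mg/kg.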

Compound 4, dose for half-maximal effect: > 100 mg/kg
Compound 4: no number, only a limit; the forecaster's own chance of this, stated with the estimate: 30%; middle value at least 2.2-fold (0.34 log units) from the limit.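

At this position, on a saturated chain carbon, four bonds along the chain from an aromatic nitrogen, the group of 8 heavy atoms in place of the group of 6 heavy atoms gives an at least 2.8-fold higher number from compound 2 to compound 4 (0.45 log units; beyond the scatter) in this assay. From the compounds shown here alone, compound 4 gives > 100 mg/kg, which is a limit and not a number, so the full size of this step stays unknown. Compound 2 remains the only compound with a number: the limit of > 100 mg/kg in this assay, at which 3 of the 4 values shown sit.

The compounds shown do not tell whether an ethyl group or a cyclohexyl ring on the thiourea would give a number in this assay.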